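This account rests on a few compounds, and the source may have more. Where it says the series, first, only, none or still open, it means among the compounds named here.

Compound 1 `Cc1cn(C2CCN(Cc3cccc(Oc4ccc(F)c(F)c4)c3)CC2)c(=O)[nH]c1=O` is examined in an ADME assay on MRC5 cells (Homo sapiens) for cytotoxicity, read by fluorescence and resazurin assay, with a stated time of 3 days; on this read-out higher numbers stand for weaker inhibition and lower numbers for stronger inhibition. In this assay compound 1 gives > 64000 nM, which is a limit of the assay and not a number. Compound 2 `Cc1cn(C2CCN(Cc3ccnc(Oc4ccccc4)c3)CC2)c(=O)[nH]c1=O` likewise gives only a limit, > 64000 nM. Compound 3 `Cc1cn(C2CCN(Cc3ccnc(Oc4cccc(Cl)c4)c3)CC2)c(=O)[nH]c1=O` also gives a limit, > 64000 nM. The step that the two limits leave unreadable from compound 2 to compound 3 is therefore not readable. Compound 4 `Cc1cn(C2CCN(Cc3cccc(Oc4ccc(Cl)c(C(F)(F)F)c4)c3)CC2)c(=O)[nH]c1=O` differs from compound 1 in one place: 4-chloro-3-(trifluoromethyl)phenyl in place of 3,4-difluorophenyl on an oxygen on an aromatic ring. Within the data shown here, no measured step bears directly on this change, and every value shown sits at the limit of > 64000 nM in this assay, at which 3 of the 3 values shown sit. With all three compounds at the limit, no step beyond the scatter is expected from compound 1 to compound 4. Compound 4 is expected to give about 100000 nM, with a range from 30000 nM to 300000 nM. The expected step that the limit leaves unreadable from compound 1 to compound 4 is thus estimated to be negligible, with the value most likely reported again only as a limit.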

Compound 4, half-maximal inhibitory concentration: 5280 nM
Compound 4: the middle estimate sits 19-fold (1.28 log units) above what was measured; the whole stated range lies above it.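

Replacing 3,4-difluorophenyl with 4-chloro-3-(trifluoromethyl)phenyl on an oxygen on an aromatic ring gives, in this assay, an at least 12-fold lower number from compound 1 to compound 4 (1.08 log units; beyond the scatter). The group in this place can therefore bring the read-out off the limit, which the earlier compounds could not show: the limit of > 64000 nM in this assay, at which 3 of the 4 values shown sit.

On these data alone, the chloro and the trifluoromethyl enter together, so it stays open whether either one alone would give this step. As far as these compounds go, it also stays open where the value would fall with a phenyl carrying an amine or a carboxylic acid in this place.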